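This account rests on a few compounds, and the source may have more. Where it says the series, first, only, none or still open, it means among the compounds named here.

Of the compounds shown here, two have been measured in an ADME assay on microsomes from liver (Homo sapiens) for metabolic stability, read by LC-MS, with a stated time of 30 min, tested at 1 uM; a lower number here means that less of the compound is left, a higher number that more of the compound is left. Compound 1 `O=C(NCc1ccc(S(=O)(=O)c2ccccc2)cc1)c1ccc2ncncc2c1` leaves 24% of the compound after the stated time. Compound 2 `O=C(NCc1ccc(S(=O)(=O)N2CCCCC2)cc1)c1cc2cnccc2s1` gives 15% in this assay, a number that lies within the usual scatter of the value for compound 1, so the two cannot be told apart on this measure. Compound 3 `O=C(NCc1ccc(S(=O)(=O)N2CCCCC2)cc1)c1cc2ccncc2o1` is a variant of compound 2, altered only on a carbonyl carbon: a group of 9 heavy atoms (7 carbon, 1 nitrogen, 1 oxygen; one five-membered aromatic ring with 1 hetero atom, one six-membered aromatic ring with 1 hetero atom) in place of a group of 9 heavy atoms (7 carbon, 1 nitrogen, 1 sulfur; one five-membered aromatic ring with 1 hetero atom, one six-membered aromatic ring with 1 hetero atom), on a carbonyl carbon. Among the compounds with values here, no step of this kind has been measured here, so the change expected is small, none beyond the scatter: a number 3 percentage points higher from compound 2 to compound 3 (within the scatter). Compound 3 is expected to give about 18% in this assay, within a range from 8% to 35%.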

Compound 3, percent of the compound remaining: 56%
The estimate for compound 3 lay 38 percentage points below the measured number; the whole stated range lies below it.
By their numbers in this assay, from the lowest: compounds 2 and 1 (each within the scatter of the next); then compound 3.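

At this place on a carbonyl carbon, the result shows that the group matters greatly for this assay (a number 41 percentage points higher from compound 2 to compound 3 (beyond the scatter)). The two groups match in their counts of heavy atoms, rings and hydrogen-bond acceptors, yet one oxygen enters where one sulfur leaves, so identical counts do not ensure similar numbers here. Nothing available explains the rise. Still open, as far as these compounds go, is whether a plain phenyl group on this carbonyl carbon would give a number as high, and whether the same swap would have a similar effect on another core.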